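Hydroxy added to the phenyl ring of compound 2

This account rests on a few compounds, and the source may have more. Where it says the series, first, only, none or still open, it means among the compounds named here.

In a functional assay on LoVo cells (Homo sapiens) for inhibition, read by MTT assay, with a stated time of 24 h (on this read-out lower numbers stand for stronger inhibition and higher numbers for weaker inhibition), compound 1 `CC1(C)[C@H]2CC[C@]1(C)N(Cc1cn(-c3ccccc3Cl)nn1)C(=O)C2` gives 190 nM and compound 2 `CC1(C)[C@H]2CC[C@]1(C)N(Cc1cn(-c3ccccc3)nn1)C(=O)C2` gives 50 nM, the lower of the two numbers. Compound 3 `CC1(C)[C@H]2CC[C@]1(C)N(Cc1cn(-c3ccccc3O)nn1)C(=O)C2` carries hydroxy in place of hydrogen on an aromatic carbon, ortho to a large group: hydroxy in place of hydrogen on an aromatic carbon. Among the measured compounds shown here, the only measured step that bears on this is modest: a 3.8-fold lower number from compound 1 to compound 2 (0.58 log units; beyond the scatter), with hydrogen in place of chloro on an aromatic carbon. For the measured compounds named here, no hydroxy compound has been measured, so this guide is loose. A similarly modest rise is expected: a 2.4-fold higher number from compound 2 to compound 3 (0.38 log units; beyond the scatter). In this assay the estimate for compound 3 is 120 nM, with an expected range from 35 nM to 400 nM.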

Compound 3, half-maximal inhibitory concentration: 540 nM
Compound 3: the middle estimate sits 4.5-fold (0.65 log units) below what was measured, and the stated range ends below it.
By their numbers in this assay, from the lowest: compound 2; then compound 1; then compound 3.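

In this assay, the position ortho to a large group proves sensitive to hydroxy: the change gives a large loss, with an 11-fold higher number from compound 2 to compound 3 (1.03 log units; beyond the scatter). Hydroxy also fares worse than chloro at this place, with a 2.8-fold higher number from compound 1 to compound 3 (0.45 log units; beyond the scatter), so of the two groups tried here, both raise the number over plain phenyl, and hydroxy raises it further. No data given here explain this difference between the groups.

As far as these compounds go, whether methoxy or an amine at this position would follow hydroxy or chloro remains open. So does whether any group here can give a lower number than hydrogen does in compound 2.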